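Isopropyl for methyl on the carboxy side chain

The source may hold more compounds than are shown below. What is called first, only, known or untested is meant among the compounds shown, and "the series" means these compounds.

Values measured so far in a functional assay on PC-3 cells (Homo sapiens) for antiproliferative activity, read by MTT assay, with a stated time of 24 h (a higher number here means a weaker inhibitor, a lower number a stronger inhibitor), are as follows.
- compound 1 `CCn1c(C(=O)N[C@H](C)CO)ccc1C(CC)(CC)c1ccc(OCS(=O)(=O)c2ccccc2)c(C)c1` gives 7790 nM
- compound 2 `CCn1c(C(=O)N[C@H](C)C(=O)O)ccc1C(CC)(CC)c1ccc(OCS(=O)(=O)c2ccccc2)c(C)c1` gives 20100 nM

Compound 2 holds the higher of the two numbers, so it is the weaker of the pair, and compound 1 is its nearest neighbour. The next step leads to compound 3 `CCn1c(C(=O)N[C@@H](C(=O)O)C(C)C)ccc1C(CC)(CC)c1ccc(OCS(=O)(=O)c2ccccc2)c(C)c1`, which differs from compound 2 by isopropyl in place of methyl on a saturated chain carbon bound to an amide-type nitrogen and a carbonyl carbon and carries isopropyl in place of methyl on a saturated chain carbon bound to an amide-type nitrogen and a carbonyl carbon.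

Within the data shown here, no measured step exchanges methyl for isopropyl. Among the measured compounds shown here, the only step at that chain carbon is modest, a 2.6-fold higher number from compound 1 to compound 2 (0.41 log units; beyond the scatter) on exchanging hydroxymethyl for carboxy, and it is a different change, so it gives only a rough size. A step of about that size or smaller is expected in this assay and may not clear the scatter. The data do not fix the direction, and a slightly lower number is only a tentative assumption. The estimated move is a 1.4-fold lower number from compound 2 to compound 3 (0.16 log units; within the scatter) with wide uncertainty in either direction. The expected value for compound 3 is 14000 nM with an estimated range from 6000 nM to 35000 nM in this read-out.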

Compound 3, half-maximal inhibitory concentration: 3070 nM
Estimate against measurement, compound 3: 4.6-fold (0.66 log units) above, outside the stated range (below it).
By their numbers in this assay, from the lowest: compound 3; then compound 1; then compound 2.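

Among these compounds, exchanging methyl for isopropyl on the saturated chain carbon bound to an amide-type nitrogen and a carbonyl carbon gives a 6.5-fold lower number from compound 2 to compound 3 (0.82 log units; beyond the scatter) in this assay, the largest step so far and the first to show that this carbon can move the read-out more than the earlier change from hydroxymethyl to carboxy did. The carboxy group therefore does not fix a compound at the weak end of the series: compound 3 keeps it, yet the whole side-chain change gives a 2.5-fold lower number from compound 1 to compound 3 (0.40 log units; beyond the scatter), although that step alters two features at once and cannot separate their contributions. No measured evidence bears on the origin of the isopropyl gain.

On these data alone, it remains open whether a larger group at this carbon, such as isobutyl, tert-butyl or benzyl, would extend the change seen with isopropyl or reverse it. As far as these compounds go, it is also open whether the isopropyl gain depends on the carboxylic acid, which a side chain carrying isopropyl with hydroxymethyl, a primary amide or a methyl ester in its place would test.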